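Removing the propoxy chain: a phenol analogue of compound 1

The source may report more compounds than this note shows. Statements on the series, on what has been measured and on what is new or still open speak of the compounds shown alone.

Compound 1 `CCCOc1ccc2c(c1)SCC(=O)N2` stands second highest of the three numbers measured in an assay on isolated protein for inhibition of Amine oxidase [flavin-containing] A (Homo sapiens), read by fluorescence and spectrophotometry, with a stated time of 20 min (a higher number here means a weaker inhibitor, a lower number a stronger inhibitor), where compound 1 gives 6510 nM. Compound 2 `O=C1CSc2cc(OCC3CCCCC3)ccc2N1` gives 1170 nM, and compound 3 `O=C1CSc2cc(OCCCc3ccccc3)ccc2N1` gives 96800 nM. The change to compound 4 `O=C1CSc2cc(O)ccc2N1` is hydrogen in place of propyl on an oxygen on an aromatic ring. Both measured steps touch the same oxygen on an aromatic ring: enlarging the chain end gave a 5.6-fold lower number from compound 1 to compound 2 (0.75 log units; beyond the scatter), while extending the chain with phenyl gave a 15-fold higher number from compound 1 to compound 3 (1.17 log units; beyond the scatter). Neither shrinks the chain, so the bearing is indirect; a modest step toward a higher number is expected in this assay. Compound 4 is therefore estimated at 20000 nM, between 5000 nM and 80000 nM, which would mean a 3.1-fold higher number from compound 1 to compound 4 (0.49 log units; beyond the scatter) is expected.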

Compound 4, half-maximal inhibitory concentration: 19200 nM
Compound 4: the middle estimate sits 1.0-fold (0.02 log units) above what was measured; low and high end bracket the measured number.
By their numbers in this assay, from the lowest: compound 2; then compound 1; then compound 4; then compound 3.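

Removing the propyl from the oxygen on the aromatic ring gave, in this assay, a 2.9-fold higher number from compound 1 to compound 4 (0.47 log units; beyond the scatter). The earlier steps shown here only enlarged or extended the group on this oxygen, whereas this one shows that the core with a bare hydroxy keeps a measurable number, though a higher one than with propoxy. Nothing available explains this shift. The compounds shown leave open how a methyl or ethyl on this oxygen would read, and whether the number would change stepwise from hydroxy to propoxy. As far as these compounds go, an amine in place of the hydroxy also remains open.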